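This account rests on a few compounds, and the source may have more. Where it says the series, first, only, none or still open, it means among the compounds named here.

Three compounds of the series have numbers in an ADME assay on microsomes from liver (Rattus norvegicus) for metabolic stability (a higher number here means faster removal of the compound, a lower number slower removal), so far. Compound 1 `COc1cc(-c2nnc(S(=O)(=O)C3CCC3)[nH]2)ccc1-c1cnc(OCC(C)C)c(Cl)c1` gives 61 uL/min, the highest of the three. Compound 3 `Cc1ccc(Cl)c(Oc2ncc(-c3cc(F)c(-c4nnc(S(=O)(=O)CC5CC5)[nH]4)cc3F)cc2Cl)c1` gives 52 uL/min, a number within the scatter of that of compound 1. Compound 2 `CC(C)COc1ncc(-c2cc(F)c(-c3nnc(S(C)(=O)=O)[nH]3)cc2F)cc1Cl` gives 23 uL/min, which lies beyond the scatter from the number of compound 1. Compound 4 `COc1cc(-c2nnc(S(=O)(=O)C3CCC3)[nH]2)c(F)cc1-c1cnc(OCC(C)C)c(Cl)c1` has not yet been run in this assay. It differs from compound 1 in one place: fluoro in place of hydrogen on an aromatic carbon. Among the compounds with values here, no pair of measured compounds shows this change on its own, so its size is unknown from the data in hand. In this assay the expected step is a 1.2-fold lower number from compound 1 to compound 4 (0.09 log units; within the scatter), none beyond the scatter. Compound 4 is thus expected near 50 uL/min, within 25 uL/min to 100 uL/min.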

Compound 4, intrinsic clearance in a liver preparation (reported as CLH), per the amount of preparation that the assay uses: 27 uL/min
Estimate against measurement, compound 4: 1.9-fold (0.27 log units) above, within the range that was stated.
By their numbers in this assay, from the lowest: compounds 2, 4, 3 and 1 (each within the scatter of the next, the first and the last beyond it).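

In this assay, fluoro in place of hydrogen on the aromatic carbon para to a methoxy group gives a 2.3-fold lower number from compound 1 to compound 4 (0.35 log units; beyond the scatter). Within the data shown here, this is the first one-place step, and it shows that a single added fluorine atom at this position is enough to move the number beyond the scatter. Nothing in hand accounts for the step.

As far as these compounds go, whether a nitrile or a trifluoromethyl group on this carbon would give a similar step remains open. Also open, from the compounds shown here alone, is whether the fluoro step would hold with an amine in place of the methoxy group.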